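Removing the ethynyl from the triazole of compound 2

The source may report more compounds than this note shows. Statements on the series, on what has been measured and on what is new or still open speak of the compounds shown alone.

Measured compounds:
- compound 1 `Cc1cn(C[C@H]2CN(c3ccc(C4=CCS(=O)(=O)CC4)c(F)c3)C(=O)O2)nn1`: 25000 nM
- compound 2 `C#Cc1cn(C[C@H]2CN(c3ccc(C4=CCS(=O)(=O)CC4)c(F)c3)C(=O)O2)nn1`: > 200000 nM

In an assay for binding affinity to Amine oxidase [flavin-containing] A (Homo sapiens) (on this read-out lower numbers stand for stronger inhibition and higher numbers for weaker inhibition), compound 1 gives 25000 nM. Compound 2 reaches only the limit of the measurement, > 200000 nM, so for compound 2 no exact number is known; it is the weaker of the two, as the step of an at least 8.0-fold higher number from compound 1 to compound 2 (0.90 log units; beyond the scatter) shows, and the limit of > 200000 nM in this assay, at which 1 of the 2 values shown sits, tells where that value sits.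

Compound 3 `O=C1O[C@@H](Cn2ccnn2)CN1c1ccc(C2=CCS(=O)(=O)CC2)c(F)c1` differs from compound 2 in one place: hydrogen in place of ethynyl on an aromatic carbon. Among the measured compounds shown here, the only measured step, an at least 8.0-fold higher number from compound 1 to compound 2 (0.90 log units; beyond the scatter), concerns a different exchange, methyl to ethynyl, and so bears on this step only indirectly: it shows that the ethynyl on that ring carbon is tolerated worse than a methyl. Whether the bare ring hydrogen of compound 3 behaves like the methyl of compound 1 or like the ethynyl of compound 2 cannot be read from these two compounds alone.

The expected step from compound 2 to compound 3 is therefore an at least 4.0-fold lower number from compound 2 to compound 3 (0.60 log units; beyond the scatter), towards stronger inhibition, with wide uncertainty. For compound 3 an inhibition constant of 50000 nM is expected, within 15000 nM to 200000 nM.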

Compound 3, inhibition constant: 3400 nM
Compound 3: the middle estimate sits 15-fold (1.17 log units) above what was measured, and the stated range ends above it.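

In this assay, removing the substituent from this aromatic carbon altogether gives stronger inhibition than either group seen earlier: replacing methyl with hydrogen produces a 7.4-fold lower number from compound 1 to compound 3 (0.87 log units; beyond the scatter), and replacing ethynyl with hydrogen produces an at least 58-fold lower number from compound 2 to compound 3 (1.76 log units; beyond the scatter). Among these three compounds, the order at this position is now complete, with hydrogen giving the lowest number, methyl a higher one and ethynyl the highest, so both carbon groups weaken inhibition relative to the unsubstituted ring. The second step gives only a minimum size, since compound 2 has no exact value: the limit of > 200000 nM in this assay, at which 1 of the 3 values shown sits.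

These compounds carry only hydrogen and two carbon groups at this position, so they leave open whether an amine, a hydroxymethyl group or a carboxylic acid there would also weaken inhibition relative to hydrogen. They also cannot separate what distinguishes methyl from ethynyl, and a longer chain such as ethyl or propyl would be needed to show whether the number keeps rising as the carbon group grows.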